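Aryl to styryl on the triazole: compound 1 to compound 4

The compounds below may be only part of what the source reports. "The series", "measured", "known", "first", "only" and "open" are said of these compounds alone.

Measured in a functional assay on MCF7 cells (Homo sapiens) for antiproliferative activity; a higher number here means a weaker inhibitor, a lower number a stronger inhibitor:
- compound 1 `CO[C@@H]1[C@@H](O)[C@@H](O)[C@H](Oc2ccc3c(c2C)OC(=O)C(n2cc(-c4ccc(C)cc4)nn2)C3)OC1(C)C`: > 100000 nM, a limit
- compound 2 `COc1ccc(-c2cn(-c3cc4ccc(O)c(C)c4oc3=O)nn2)cc1`: > 100000 nM, a limit
- compound 3 `Cc1c(O)ccc2cc(-n3cc(-c4ccc(N(C)C)cc4)nn3)c(=O)oc12`: > 100000 nM, a limit

Within the data shown here, no number has been measured so far, and the data show only (the limit of > 100000 nM in this assay, at which 3 of the 3 values shown sit). Compound 1 therefore gives no number to start from, and its > 100000 nM is a limit of the assay.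

Compound 4 `CO[C@@H]1[C@@H](O)[C@@H](O)[C@H](Oc2ccc3c(c2C)OC(=O)C(n2cc(/C=C/c4ccccc4)nn2)C3)OC1(C)C` keeps the core of compound 1 and has 2-phenylethenyl in place of 4-methylphenyl on an aromatic carbon of the five-membered aromatic ring with 3 nitrogen (2-phenylethenyl in place of 4-methylphenyl on an aromatic carbon). The change adds 1 double bond outside aromatic rings.

Among the measured compounds shown here, one measured step bears on this, and only loosely: a step that the two limits leave unreadable from compound 2 to compound 3. That step puts dimethylamino in place of methoxy on an aromatic carbon, a different change on a different core, and it gives no size to carry over.

With no readable step available, none is expected in this assay, and no direction can be assigned. Another limit is the most likely report. The expected step is a number no higher from compound 1 to compound 4 (the limit leaves the size open). The estimate for compound 4 is 100000 nM, with an expected range of 30000 nM to 200000 nM.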

Compound 4, half-maximal inhibitory concentration: 14600 nM
Compound 4: the middle estimate sits 6.8-fold (0.84 log units) above what was measured; the measured number lies below the stated range.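

In this assay, compound 4 gives 14600 nM, the only measured number among the compounds shown. Compound 1 gives > 100000 nM, which is a limit of the assay and not a number. Placing 2-phenylethenyl in place of 4-methylphenyl on an aromatic carbon of the five-membered aromatic ring with 3 nitrogen gives an at least 6.8-fold lower number from compound 1 to compound 4 (0.83 log units; beyond the scatter), so the group at this position can move the read-out on this core, and the size of the step is a minimum only.

On these data alone, how far the step really reaches stays open, and most of the set gives no number to compare with: the limit of > 100000 nM in this assay, at which 3 of the 4 values shown sit. Also open is whether the double bond outside aromatic rings carries the change or whether the loss of the methyl on the phenyl ring does; a saturated 2-phenylethyl group and a 2-(4-methylphenyl)ethenyl group at the same position would separate the two.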